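Shifting the carboxy group at the far end of compound 2

This account rests on a few compounds, and the source may have more. Where it says the series, first, only, none or still open, it means among the compounds named here.

Three compounds share one core. Compound 1 `COC(=O)c1ccc(OCCCCOc2ccc(C(=O)CC3CCCC3)c(O)c2C)cc1` stands at "not determined" (no result reported) in an assay on HEK293 cells for positive allosteric modulation of metabotropic glutamate receptor 2 (Rattus norvegicus), read by thallium flux, with a stated time of 2.5 min (on this read-out lower numbers stand for an effect already at smaller amounts and higher numbers for an effect only at larger amounts of compound), so no result is reported for it. Compound 2 `Cc1c(OCCCCOc2ccc(C(=O)O)cc2F)ccc(C(=O)CC2CCCC2)c1O` gives 639 nM in this assay, the highest of the two numbers in hand, and compound 3 `Cc1c(OCCCCOc2ccc(C(=O)O)cc2F)ccc(C(=O)CC(C)C)c1O` gives 102 nM. Within the data shown here, the one measured step, a 6.3-fold lower number from compound 2 to compound 3 (0.80 log units; beyond the scatter), concerns the group on the saturated chain carbon bound to the carbonyl carbon, not the aryl end of the chain.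

Compound 4 `Cc1c(OCCCCOc2cccc(C(=O)O)c2)ccc(C(=O)CC2CCCC2)c1O` differs from compound 2 only at that aryl end: 3-carboxyphenyl in place of 4-carboxy-2-fluorophenyl on an oxygen on a saturated carbon. Among the measured compounds shown here, no measured step touches this part of the molecule, so nothing in hand tells how moving the carboxy group and removing the fluorine will play out. The most defensible expectation for compound 4 is therefore a number close to that of compound 2, with a step of a 1.3-fold higher number from compound 2 to compound 4 (0.10 log units; within the scatter) that stays within the scatter. For the measured compounds named here, compound 4 is estimated at 800 nM, plausibly between 250 nM and 2500 nM, with the wide range reflecting that this change has no measured precedent here.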

Compound 4, half-maximal effective concentration: 451 nM
For compound 4 the middle estimate is 1.8-fold (0.25 log units) above the measured one, and the stated range covers the measured number.
By their numbers in this assay, from the lowest: compound 3; then compounds 4 and 2 (each within the scatter of the next).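

In this assay, placing 3-carboxyphenyl where 4-carboxy-2-fluorophenyl stood on an oxygen on a saturated carbon gives a 1.4-fold lower number from compound 2 to compound 4 (0.15 log units; within the scatter), so the two cannot be told apart on this read-out. Among these compounds, this is the first measured step at this part of the molecule, and it lies within the scatter, whereas the step that exchanges cyclopentyl for isopropyl, a 6.3-fold lower number from compound 2 to compound 3 (0.80 log units; beyond the scatter), lies beyond it. No evidence is at hand that bears on this result.

As far as these compounds go, the swap moves the carboxy group and removes the fluorine at once, so it remains open how each change acts alone, a question that 4-carboxyphenyl without the fluorine could help to settle. Also open, from the compounds shown here alone, are how a tetrazole in place of the carboxylic acid would read and whether the isopropyl group of compound 3 would give a similar number alongside 3-carboxyphenyl.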